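This account rests on a few compounds, and the source may have more. Where it says the series, first, only, none or still open, it means among the compounds named here.

Of the compounds shown here, three have so far been measured in an assay on membranes from Sf9 cells for displacement of a labelled ligand from histamine H2 receptor (Homo sapiens), read by scintillation counting, with a stated time of 60 min; a lower number here means a stronger inhibitor, a higher number a weaker inhibitor. Compound 1 `Cc1nc(N)sc1CCCN/C(N)=N/C(=O)N[C@H](C)c1ccccc1` gives 17.8 nM, the lowest number of the three. Compound 2 `N/C(=N\C(=O)NCc1ccccc1)NC1CCc2nc(N)sc2C1` gives 513 nM, and compound 3 `N/C(=N\C(=O)NC1CCCCC1)Nc1cccc(-c2csc(N)n2)c1` gives 4470 nM; the gaps from compound 1 to each of them lie beyond the scatter. Compound 4 `Cc1nc(N)sc1CCCN/C(N)=N/C(=O)NCc1ccco1` has not yet been measured; it differs from compound 1 by (furan-2-yl)methyl in place of 1-phenylethyl on an amide-type nitrogen. Going by the values given here, no measured pair isolates this change, so the expectation rests on the structural change alone. A modest weakening is anticipated, though it may not exceed the scatter. The expected step is a 2.2-fold higher number from compound 1 to compound 4 (0.35 log units; beyond the scatter). Compound 4 is accordingly estimated at 40 nM, within a range from 10 nM to 160 nM.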

Compound 4, inhibition constant: 10.5 nM
Beside the measured number, compound 4's estimate is 3.8-fold (0.58 log units) above it; low and high end bracket the measured number.
By their numbers in this assay, from the lowest: compounds 4 and 1 (each within the scatter of the next); then compound 2; then compound 3.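

In this assay, exchanging 1-phenylethyl for (furan-2-yl)methyl on the amide-type nitrogen gives a 1.7-fold lower number from compound 1 to compound 4 (0.23 log units; within the scatter) and so leaves the reading unchanged within the scatter. Going by these compounds alone, this position therefore accepts a five-membered aromatic ring with one oxygen, and no defined stereocentre, as readily as a six-membered aromatic ring of carbon only, which the earlier compounds could not show. Nothing measured here explains why the two groups read alike. From the compounds shown here alone, whether a thiophene or pyridine ring on this nitrogen would also read alike remains open. So does the effect of a longer chain linking the ring to the nitrogen.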